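Chloro in Place of Methyl, Read Across Two Positions

The compounds below may be only part of what the source reports. "The series", "measured", "known", "first", "only" and "open" are said of these compounds alone.

Three compounds built on one shared core were examined in an assay on HEK293 cells for positive allosteric modulation of metabotropic glutamate receptor 5 (Homo sapiens), read by FLIPR; on this read-out higher numbers stand for an effect only at larger amounts of compound and lower numbers for an effect already at smaller amounts. In this assay compound 1 `O=C(c1ccc(Cl)cc1)N1CC(c2nc(-c3cccc(F)c3)no2)C1` gives 2500 nM, while compound 2 `Cc1ccc(C(=O)N2CC(c3nc(-c4cccc(F)c4)no3)C2)cc1` gives 6800 nM. These two differ in a single place, (chloro in place of methyl on an aromatic carbon), and that change produced a 2.7-fold lower number from compound 2 to compound 1 (0.43 log units; beyond the scatter).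

Compound 3 `Cc1cccc(-c2noc(C3CN(C(=O)c4ccccc4F)C3)n2)c1` returned no number in this assay, only > 10000 nM, which is a limit of the assay rather than a measured value, as noted in the limit of > 10000 nM in this assay, at which 1 of the 3 values shown sits. How the core of compound 3 differs from the core of compound 2 is not broken down here.

Compound 4 `O=C(c1ccccc1F)N1CC(c2nc(-c3cccc(Cl)c3)no2)C1` has not yet been measured. It differs from compound 3 by chloro in place of methyl on an aromatic carbon. Among the compounds with values here, the place is not identical to the one in the step from compound 2 to compound 1: there the chloro sits para to a large group, here meta to a large group, so this is the same kind of change rather than the same change. Resting on the modest gain seen in a 2.7-fold lower number from compound 2 to compound 1 (0.43 log units; beyond the scatter), compound 4 is expected to show an at least 1.4-fold lower number from compound 3 to compound 4 (0.15 log units; that floor lies within the scatter), starting from a limit. The estimate for compound 4 in this assay is 7000 nM, expected to fall between 2500 nM and 20000 nM.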

Compound 4, half-maximal effective concentration: > 10000 nM
Compound 4 ended at the assay's limit (the forecaster's own chance of this, stated with the estimate: 45%); at least 1.4-fold (0.15 log units) between middle value and limit.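

Within the data shown here, compound 3 and compound 4 both ended at a limit rather than at a number, so no step between them can be read in this assay: the limit of > 10000 nM in this assay, at which 2 of the 4 values shown sit. The compounds shown leave open whether 3-chlorophenyl in place of 3-methylphenyl changes the response on this core at all, and in which direction.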